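Aryl change on the ring amine nitrogen: compound 3

A few compounds are considered here, and "the series" means these few. Any claim that something is new, unique, unknown or untested is made for them only; others in the source may bear on it.

Measured so far:
compound 1 `Nc1scc(CN2CCN(c3ccc(F)c(F)c3)CC2)c1C(=O)c1ccc(Cl)cc1` — 1%
compound 2 `Nc1scc(CN2CCN(c3c(F)cccc3F)CC2)c1C(=O)c1ccc(Cl)cc1` — 4%

In an assay on CHO cells for displacement of a labelled ligand from adenosine receptor A3 (Homo sapiens), read by scintillation counting, with a stated time of 120 min, tested at 10 uM (a lower number here means less inhibition, a higher number more inhibition at the concentration tested (going by the name of the read-out)), compound 1 gives 1% and compound 2 gives 4%. Compound 2 holds the higher of the two numbers, but the step of a number 3 percentage points higher from compound 1 to compound 2 (within the scatter) is within the scatter, so the two compounds are not separated by this read-out.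

Compound 3 `Nc1scc(CN2CCN(c3cc(Cl)ccc3Cl)CC2)c1C(=O)c1ccc(Cl)cc1` is not yet measured. Its change from compound 2 is 2,5-dichlorophenyl in place of 2,6-difluorophenyl on an amine nitrogen in a ring. For the measured compounds named here, the one measured step that bears on it, a number 3 percentage points higher from compound 1 to compound 2 (within the scatter), also exchanges the group on the amine nitrogen in the ring and gave no movement beyond the scatter. With both measured compounds near the bottom of the scale, the expected step of no change at the digits printed from compound 2 to compound 3 (within the scatter) in this assay is none beyond the scatter. Compound 3 is therefore estimated at 4% in this assay, with a range from -6% to 16%.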

Compound 3, a percentage reported as inhibition, at one concentration (the size of the read-out at that concentration, not a potency): 1%
For compound 3 the middle estimate is 3 percentage points above the measured one, within the range that was stated.
By their numbers in this assay, from the lowest: compounds 1, 3 and 2 (each within the scatter of the next).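

In this assay the change to 2,5-dichlorophenyl on the amine nitrogen in the ring reads as a number 3 percentage points lower from compound 2 to compound 3 (within the scatter) and as no change at the digits printed from compound 1 to compound 3 (within the scatter) so the three aryl groups are not separated by this read-out. What the earlier pair did not show is that this holds with chlorine as well as fluorine on the aryl ring and with a third placement of the two halogens, at the same heavy-atom count of the group. Nothing at hand explains why these groups read alike.

Still open, going by these compounds, is whether a group without halogen on that nitrogen, such as unsubstituted phenyl, methoxyphenyl, a pyridine or a cyclohexyl ring, would move the number beyond the scatter. Also open, on these data alone, is whether a change elsewhere on the shared core, such as at the ring amine or the 4-chlorophenyl ketone, would do so.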